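Adding a Second Methoxy Group to a Weak Inhibitor

The source may report more compounds than this note shows. Statements on the series, on what has been measured and on what is new or still open speak of the compounds shown alone.

Of the compounds shown here, two have been measured in a functional assay on KB cells (Homo sapiens) for antiproliferative activity, read by MTT assay, with a stated time of 72 h; on this read-out higher numbers stand for weaker inhibition and lower numbers for stronger inhibition. Compound 1 `CN(c1ccc2[nH]c(-c3n[nH]c4ccccc34)cc2n1)S(=O)(=O)c1ccc(Br)cc1` carries a bromo group and gives 7150 nM. Compound 2 `COc1ccc(S(=O)(=O)N(C)c2ccc3[nH]c(-c4n[nH]c5ccccc45)cc3n2)cc1` has a methoxy in place of that bromo and gives 22100 nM. Among the measured compounds shown here, of the two numbers, compound 2 has the higher one, meaning weaker inhibition; the step of a 3.1-fold higher number from compound 1 to compound 2 (0.49 log units; beyond the scatter) is the only measured step available.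

Compound 3 `COc1ccc(S(=O)(=O)N(C)c2ccc3[nH]c(-c4n[nH]c5ccccc45)cc3n2)cc1OC` is not yet measured. It differs from compound 2 by methoxy in place of hydrogen on an aromatic carbon, so that the 4-methoxyphenyl becomes a 3,4-dimethoxyphenyl. For the measured compounds named here, the one known step, a 3.1-fold higher number from compound 1 to compound 2 (0.49 log units; beyond the scatter), concerns swapping bromo for methoxy and does not describe adding a second methoxy group; it bears on the new step only loosely, showing that a change on this ring can move the number by a modest amount. With nothing closer to go on, no step beyond the usual scatter is expected in this assay for compound 3, perhaps a slight drift toward higher numbers, a 1.2-fold higher number from compound 2 to compound 3 (0.07 log units; within the scatter). Compound 3 is therefore estimated at 26000 nM, with a range from 8000 nM to 80000 nM.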

Compound 3, half-maximal inhibitory concentration: 10100 nM
Estimate against measurement, compound 3: 2.6-fold (0.41 log units) above, and the stated range covers the measured number.
By their numbers in this assay, from the lowest: compounds 1 and 3 (each within the scatter of the next); then compound 2.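

In this assay, adding a methoxy group that turns the 4-methoxyphenyl into a 3,4-dimethoxyphenyl gives a 2.2-fold lower number from compound 2 to compound 3 (0.34 log units; beyond the scatter). Among the compounds shown here, this is the first sign that this carbon of the ring, ortho to a methoxy group, is not indifferent to substitution, and the change runs toward stronger inhibition, the opposite direction to a 3.1-fold higher number from compound 1 to compound 2 (0.49 log units; beyond the scatter), so a methoxy group on this ring does not weaken inhibition in every case. The second methoxy group also brings the number back to that of the bromo compound, a 1.4-fold higher number from compound 1 to compound 3 (0.15 log units; within the scatter), so compound 1 and compound 3 cannot be told apart here, although nothing available explains why this added group moves the number.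

On these data alone, it remains open whether this gain is particular to methoxy or would also appear with a different group on the same carbon, such as a hydroxyl, a fluoro or an amine. As far as these compounds go, it is equally open whether a longer chain, such as ethoxy, would keep the gain, lose it or extend it.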